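Endothelial lipase series: N-substituent change from compound 3 to 4

The compounds below may be only part of what the source reports. "The series", "measured", "known", "first", "only" and "open" are said of these compounds alone.

Measured so far:
- compound 1, `Nc1c(C(=O)N[C@@H]2CC[C@H](c3ccccc3)C2)[nH]c(=O)[nH]c1=O`, 175 nM
- compound 2, `Nc1c(C(=O)N[C@@H]2CCCc3c(OCc4ccccc4)cccc32)[nH]c(=O)[nH]c1=O`, 49 nM
- compound 3, `CC(C)Cn1c(=O)[nH]c(C(=O)N[C@H]2CC[C@@H](c3ccccc3)CC2)c(O)c1=O`, 59 nM

In an assay on cells for inhibition of endothelial lipase (Homo sapiens), read by LC-MS, with stated times of 10 min and 30 min (on this read-out lower numbers stand for stronger inhibition and higher numbers for weaker inhibition), compound 3 stands second highest of the three numbers. Its nearest neighbour is compound 2, whose value of 49 nM lies within the scatter of compound 3, so no order between the two can be read. Compound 1, with 175 nM, sits beyond the scatter on the higher side, so compound 1 is the weaker of that pair.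

Compound 4, `O=C(N[C@H]1CC[C@@H](c2ccccc2)CC1)c1[nH]c(=O)n(CCO)c(=O)c1O`, differs from compound 3 in one place: hydroxymethyl in place of isopropyl on a saturated chain carbon bound to an aromatic nitrogen. No step between measured compounds touches this position, so the direction of the change is not shown by the data. The expectation is a step from compound 3 to compound 4 of a 1.4-fold higher number from compound 3 to compound 4 (0.13 log units; within the scatter) in this assay, that is, none beyond the scatter. Compound 4 is accordingly estimated at 80 nM, with a range from 30 nM to 220 nM.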

Compound 4, half-maximal inhibitory concentration: 80 nM
The estimate for compound 4 equals the measured number at the digits printed; measured number inside the range.
By their numbers in this assay, from the lowest: compounds 2, 3 and 4 (each within the scatter of the next); then compound 1.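

In this assay, going by these compounds alone, the first step at this position, hydroxymethyl in place of isopropyl on a saturated chain carbon bound to an aromatic nitrogen, reads a 1.4-fold higher number from compound 3 to compound 4 (0.13 log units; within the scatter) and so gives no order between the two compounds. Within the data shown here, the same difference, cut one bond further out, is isobutyl to 2-hydroxyethyl: a hydrogen-bond donor and a hydrogen-bond acceptor enter here and the read-out stays within the scatter, which the earlier compounds, with no step at this position, could not show. No measurement at hand bears on the reason for this result.

Open, from the compounds shown here alone, is whether a longer chain such as 3-hydroxypropyl, or an amine or a carboxylic acid at the end of this chain, would also stay within the scatter of compound 3. Also open, going by these compounds, is whether a methyl ether in place of the hydroxyl of compound 4 would read the same.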